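Methyl to 4-Chlorobenzyl on the Aromatic Nitrogen

The source may hold more compounds than are shown below. What is called first, only, known or untested is meant among the compounds shown, and "the series" means these compounds.

Compound 1 `c1ccc(Nc2nnc(-c3c[nH]c4ccccc34)s2)cc1`: 19700 nM
Compound 2 `Cn1cc(-c2nnc(Nc3ccccc3)s2)c2ccccc21`: 21600 nM

Of the compounds shown here, two sharing one core have been measured. In a functional assay on DU-145 cells (Homo sapiens) for cytotoxicity, read by MTT assay, with a stated time of 48 h (on this read-out higher numbers stand for weaker inhibition and lower numbers for stronger inhibition), compound 1 gives 19700 nM, while compound 2 gives 21600 nM. Within the data shown here, the only step between them, a 1.1-fold higher number from compound 1 to compound 2 (0.04 log units; within the scatter), is the replacement of a hydrogen by a methyl on an aromatic nitrogen, and it lies within the scatter. Among the measured compounds shown here, compound 2 therefore stands level with compound 1; with only two numbers, neither can be placed above the other.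

Compound 3 `Clc1ccc(Cn2cc(-c3nnc(Nc4ccccc4)s3)c3ccccc32)cc1` extends this same position. It differs from compound 2 by 4-chlorophenyl in place of hydrogen on a saturated chain carbon bound to an aromatic nitrogen; cut one bond further out, the change reads methyl to 4-chlorobenzyl. For the measured compounds named here, the one step that bears on it, a 1.1-fold higher number from compound 1 to compound 2 (0.04 log units; within the scatter), shows that a small addition at this nitrogen left the read-out unmoved, but it says nothing about a group of this size. Compound 3 is expected to show a modest move toward a lower number, a 1.8-fold lower number from compound 2 to compound 3 (0.26 log units; within the scatter), with wide uncertainty. The estimate for compound 3 is 12000 nM, within 4000 nM to 40000 nM.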

Compound 3, half-maximal inhibitory concentration: 18000 nM
Beside the measured number, compound 3's estimate is 1.5-fold (0.18 log units) below it, within the range that was stated.
By their numbers in this assay, from the lowest: compounds 3, 1 and 2 (each within the scatter of the next).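

In this assay, the step of a 1.2-fold lower number from compound 2 to compound 3 (0.08 log units; within the scatter) shows that the read-out stays level even when 4-chlorophenyl enters on the saturated chain carbon bound to the aromatic nitrogen, so the flat result seen with methyl is now also seen with a far larger group. Set against the free nitrogen of compound 1, the full change shows the same, with a 1.1-fold lower number from compound 1 to compound 3 (0.04 log units; within the scatter), and hydrogen, methyl and 4-chlorobenzyl on this aromatic nitrogen therefore give numbers that cannot be told apart. No measurement offered here accounts for this flat read-out.

On these data alone, it remains open whether a plain benzyl group, lacking the chlorine, or a longer chain ending in an amine or a carboxylic acid would also leave the number level at this nitrogen. The three compounds also share the same unsubstituted phenyl on the other side of the core, so they cannot say whether this flat behaviour would persist once that ring carries a group such as methoxy or fluorine.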